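This account rests on a few compounds, and the source may have more. Where it says the series, first, only, none or still open, it means among the compounds named here.

Measured compounds:
- Compound 1, `COc1cc2c(Nc3nc4ccc(C(=O)Nc5c(C)cccc5Cl)cc4s3)ncnc2cc1OCCCN1CCCCC1C`: 6700 nM
- Compound 2, `CCN(CC)CCCOc1cc2ncnc(Nc3nc4ccc(C(=O)Nc5c(C)cccc5Cl)cc4s3)c2cc1OC`: 10600 nM

In a functional assay on A549 cells (Homo sapiens) for cytotoxicity, read by WST assay, with a stated time of 72 h (on this read-out higher numbers stand for weaker inhibition and lower numbers for stronger inhibition), compound 2 gives 10600 nM, the highest of the two numbers shown, and the nearest to it, compound 1, gives 6700 nM. The step from compound 1 to compound 2 was a 1.6-fold higher number from compound 1 to compound 2 (0.20 log units; within the scatter), so the two values cannot be told apart on this read-out.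

Compound 3, `COc1cc2c(Nc3nc4ccc(C(=O)Nc5c(C)cccc5Cl)cc4s3)ncnc2cc1OCCCN1CCCC1`, has not yet been measured in this assay. It differs from compound 2 in one place: pyrrolidin-1-yl in place of diethylamino on a saturated chain carbon, three bonds along the chain from an oxygen on an aromatic ring.

Among the compounds with values here, only one measured step bears on this change, a 1.6-fold higher number from compound 1 to compound 2 (0.20 log units; within the scatter), which also swapped a ring amine for the diethylamino group at the same place and stayed within the scatter. On that basis the step is expected to be small, with no direction that can be claimed beyond the scatter; if anything, the number for compound 3 is expected to sit between compound 2 at 10600 nM and compound 1 at 6700 nM.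

The expected step from compound 2 to compound 3 is therefore a 1.3-fold lower number from compound 2 to compound 3 (0.12 log units; within the scatter). For compound 3 the estimate in this assay is 8000 nM, with a range from 3500 nM to 18000 nM.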

Compound 3, half-maximal inhibitory concentration: 38600 nM
Compound 3: middle estimate off by 4.8-fold (0.68 log units), on the low side, outside the stated range (above it).
By their numbers in this assay, from the lowest: compounds 1 and 2 (each within the scatter of the next); then compound 3.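

In this assay the amine on the saturated chain carbon, three bonds along the chain from an oxygen on an aromatic ring, turns out not to be a free choice: replacing diethylamino with pyrrolidin-1-yl gives a 3.6-fold higher number from compound 2 to compound 3 (0.56 log units; beyond the scatter) and so moves the number clearly, which the earlier step between compound 1 and compound 2 did not do. Replacing 2-methylpiperidin-1-yl with pyrrolidin-1-yl gives a 5.8-fold higher number from compound 1 to compound 3 (0.76 log units; beyond the scatter) in the same direction, leaving compound 3 as the weakest of the three, while compound 1 and compound 2 remain within the scatter of each other. A ring alone does not account for the pattern, since compound 1 carries a ring amine and still cannot be told apart from the open-chain compound 2, and no measurement shown here offers an explanation for the loss with pyrrolidin-1-yl.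

The three compounds do not show whether the loss is particular to pyrrolidin-1-yl, or whether an unsubstituted piperidin-1-yl, a morpholin-4-yl or a dimethylamino group at this place would follow compound 3 or stay with compound 1 and compound 2. Also open, on these data alone, is whether the step would hold on a 2-(diethylamino)ethyl and 2-(pyrrolidin-1-yl)ethyl pair, with the shorter chain.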